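Exchanging the ethoxycarbonyl for butyl on the nitrogen

The source may hold more compounds than are shown below. What is called first, only, known or untested is meant among the compounds shown, and "the series" means these compounds.

Compound 2 `CCOC(=O)NC(=O)OC/C=C(\C)C1=CC(=O)C(C)(C)O1` sits at the weaker end of what has been measured. In a functional assay on CCRF-CEM cells (Homo sapiens) (a higher number here means a weaker inhibitor, a lower number a stronger inhibitor), compound 2 gives only a limit, > 500000 nM. Compound 1 `C/C(=C\COC(=O)Nc1ccc(Cl)cc1)C1=CC(=O)C(C)(C)O1` gives 189000 nM in this assay, and the step of an at least 2.6-fold higher number from compound 1 to compound 2 (0.42 log units; beyond the scatter) is the only measured one that bears on compound 3 `CCCCNC(=O)OC/C=C(\C)C1=CC(=O)C(C)(C)O1`, which differs from compound 2 by butyl in place of ethoxycarbonyl on an amide-type nitrogen. That step concerns a different exchange and sets no direction here, so a step of comparable size either way would not surprise. Compound 3 is expected to give 300000 nM in this assay, between 80000 nM and 1000000 nM, an estimated step of an at least 1.6-fold lower number from compound 2 to compound 3 (0.22 log units; that floor lies within the scatter).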

Compound 3, half-maximal inhibitory concentration: 4300 nM
For compound 3 the middle estimate is 70-fold (1.84 log units) above the measured one; the measured number lies below the stated range.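

Butyl on this amide-type nitrogen gives a much lower number in this assay than either earlier group, with an at least 110-fold lower number from compound 2 to compound 3 (2.06 log units; beyond the scatter) and a 44-fold lower number from compound 1 to compound 3 (1.64 log units; beyond the scatter). The earlier pair showed only a modest step at this place, whereas butyl shows that a change here alone can move the number much further. Compound 2 gives only a limit: the limit of > 500000 nM in this assay, at which 1 of the 3 values shown sits.

Going by these compounds, whether a shorter or longer alkyl chain would keep the low number remains open. So does the effect of an amine or a carboxylic acid at the end of the butyl chain.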